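A few compounds are considered here, and "the series" means these few. Any claim that something is new, unique, unknown or untested is made for them only; others in the source may bear on it.

Measured so far in an assay on isolated protein for agonist activity at Bile acid receptor (Homo sapiens), read by FRET; on this read-out higher numbers stand for larger maximal responses and lower numbers for smaller maximal responses:

- compound 1 `O=C(O)c1ccc(C2CC2c2ccc(OCc3c(-c4c(Cl)cccc4Cl)noc3C3CC3)cc2Cl)cn1`: 101%
- compound 2 `CS(=O)(=O)NC(=O)c1ccc(C2CC2c2ccc(OCc3c(-c4c(Cl)cccc4Cl)noc3C3CC3)cc2Cl)cc1`: 100%
- compound 3 `O=C(O)c1cccc([C@H]2C[C@](O)(c3ccc(OCc4c(-c5c(Cl)cccc5Cl)noc4C4CC4)cc3Cl)C2)c1`: 100%

All three numbers sit at the level of the control. Compound 1 carries the nominally largest reading of the three, but compound 2 and compound 3 each lie within the scatter of it, so nothing separates them on this read-out. For the measured compounds named here, the series keeps the shared core of compound 1 and varies only the acid-bearing arm; across the three measured members that arm has made no visible difference to the maximal response.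

Compound 4 `O=C(O)c1cccc([C@H]2C[C@@H]2c2ccc(OCc3c(-c4c(Cl)cccc4Cl)noc3C3CC3)cc2Cl)c1` is the next member. Compared with compound 1 the change is 2-(3-carboxyphenyl)cyclopropyl in place of 2-(6-carboxypyridin-3-yl)cyclopropyl on an aromatic carbon.

Going by the values given here, no step between measured compounds is available to gauge this change directly. What the data show is that compound 1, compound 2 and compound 3 all reach the full response with differently built acid-bearing arms, which gives no reason to expect the arm of compound 4 to behave otherwise. The step from compound 1 to compound 4 is therefore expected to be none beyond the scatter, with a number 3 percentage points lower from compound 1 to compound 4 (within the scatter) in this assay. For compound 4 the expected value is 98%, with the range 86% to 108%.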

Compound 4, largest response reached (reported as efficacy), in percent of the reference or control that the assay uses: 101%
Compound 4: the middle estimate sits 3 percentage points below what was measured, and the stated range covers the measured number.
By their numbers in this assay, from the lowest: compounds 2, 3, 1 and 4 (each within the scatter of the next).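

In this assay, for the compounds shown here, 2-(3-carboxyphenyl)cyclopropyl in place of 2-(6-carboxypyridin-3-yl)cyclopropyl gives no change at the digits printed from compound 1 to compound 4 (within the scatter), the first step that can be read at a single place. At this aromatic carbon, ortho to a chloro group and para to a large group, an all-carbon aromatic ring in the arm therefore holds the maximal response at the level set by the ring with one hetero atom, and an arm drawn with defined stereocentres does the same as one drawn without them.

Open, on these data alone, is whether an amine or a primary amide in place of the carboxylic acid of 2-(3-carboxyphenyl)cyclopropyl would still reach the level of the control. This read-out also reports only the largest response, so it leaves open whether compound 1 and compound 4 reach that response at similar concentrations. No measurement at hand bears on what lies behind the unchanged response.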